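Alkyl chain extension on the amino-thiadiazole side chain

This account rests on a few compounds, and the source may have more. Where it says the series, first, only, none or still open, it means among the compounds named here.

Measured so far in a functional assay on the whole organism with Mus musculus as the target, read by paw edema, with a stated time of 360 min, at a dose of 100 mg/kg by the oral route; on this read-out higher numbers stand for a weaker effect at the one dose given and lower numbers for a stronger effect:
compound 1 `CNc1nnc(Cn2c(=O)oc3ccc(C)cc32)s1`: 107%
compound 2 `CCCNC(=S)NNC(=O)Cn1c(=O)oc2ccc(C)cc21`: 80.6%
compound 3 `CNC(=S)NNC(=O)Cn1c(=O)oc2ccc(C)cc21`: 85.8%

Compound 1 shows the highest number of the three, beyond the scatter from both compound 2 and compound 3, and thus the weakest effect at this dose. Compound 4 `CCCNc1nnc(Cn2c(=O)oc3ccc(C)cc32)s1` differs from compound 1 in one place: ethyl in place of hydrogen on a saturated chain carbon bound to a nitrogen on an aromatic ring. For the measured compounds named here, the only measured step of the same kind runs the other way, from propyl to methyl on an amide-type nitrogen: a number 5.2 percentage points higher from compound 2 to compound 3 (within the scatter). It lies within the scatter, so the reverse change, methyl to propyl, is expected to give at most a small shift, if any, toward a lower number. Compound 4 is therefore estimated at 102% (range 88% to 116%), a step of a number 5 percentage points lower from compound 1 to compound 4 (within the scatter) that is expected to stay within the scatter.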

Compound 4, a percentage reported as activity, at one dose (the size of the read-out at that dose, not a potency): 81.8%
Compound 4: the middle estimate sits 20.2 percentage points above what was measured; the measured number lies below the stated range.
By their numbers in this assay, from the lowest: compounds 2, 4 and 3 (each within the scatter of the next); then compound 1.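

Methylamino to propylamino gives a number 25.2 percentage points lower from compound 1 to compound 4 (beyond the scatter) in this assay, so on this core the chain on the nitrogen carries a real difference in the read-out at this dose. The size of this change depends on the core it sits on, a dependence the earlier pair alone could not reveal: the same change on two cores in this assay, a number 5.2 percentage points higher (within the scatter) from compound 2 to compound 3 and a number 25.2 percentage points higher (beyond the scatter) from compound 4 to compound 1, 20 percentage points apart, beyond the scatter of two such steps

As far as these compounds go, whether a longer chain such as butyl or pentyl, or a branched chain such as isopropyl, keeps the number low remains open. Also open, from the compounds shown here alone, is how a terminal amine or carboxylic acid on the propyl chain would read.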